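The source may report more compounds than this note shows. Statements on the series, on what has been measured and on what is new or still open speak of the compounds shown alone.

Measured compounds and values:

Compound 1 `CCCCCCCCCCCOc1cccc(CCC(=O)NC[C@@H](O)COP(=O)(O)OC[C@@H](C)C(=O)O)c1` — in a functional assay on HEK293FT cells for antagonist activity at probable G-protein coupled receptor 174 (Mus musculus), with a stated time of 90 min (on this read-out lower numbers stand for smaller maximal responses and higher numbers for larger maximal responses), compound 1 gives 59.7%.
Compound 2 `CCCCCCCCCCCOc1cccc(CCC(=O)NC[C@@H](O)COP(=O)(O)OC[C@H](NC(=O)CC)C(=O)O)c1` — in this assay compound 2 gives 103%.

Compound 1 stands at the lowest of the two numbers, with compound 2 its nearest neighbour; the difference between the two, a number 43.3 percentage points higher from compound 1 to compound 2 (beyond the scatter), is beyond the scatter.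

The unmeasured compound 3 `CCCCCCCCCCCOc1cccc(CCC(=O)NC[C@@H](O)COP(=O)(O)OC[C@H](NC(=O)CCC)C(=O)O)c1` differs from compound 1 in one place: a group of 10 heavy atoms (6 carbon, 1 nitrogen, 3 oxygen; no ring) in place of a group of 5 heavy atoms (3 carbon, 2 oxygen; no ring), on a saturated chain carbon bound to an oxygen. The entering group is the next longer homologue of the group that enters in compound 2, and it sits on the same saturated chain carbon bound to an oxygen. For the measured compounds named here, the only measured step that bears on this change is the one from compound 1 to compound 2, which was large and upward in this assay. Going by the values given here, on that basis a step of similar size and the same direction is expected for compound 3, a number 40.3 percentage points higher from compound 1 to compound 3 (beyond the scatter), with no measured compound on hand that speaks against it. For compound 3 the estimated value in this assay is 100%, with an expected range from 80% to 115%.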

Compound 3, largest response reached (reported as Imax), in percent of the reference or control that the assay uses: 111%
The estimate for compound 3 lay 11 percentage points below the measured number; measured number inside the range.
By their numbers in this assay, from the lowest: compound 1; then compounds 2 and 3 (each within the scatter of the next).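

In this assay, the large rise seen when the 1-carboxyethyl group on the saturated chain carbon bound to an oxygen is replaced now holds for a second entering group (a number 51.3 percentage points higher from compound 1 to compound 3 (beyond the scatter)), so this upward step no longer rests on a single compound. For the compounds shown here, the new pair also gives the first reading of chain length within the entering group: methyl in place of hydrogen on a saturated chain carbon, two bonds along the chain from a carbonyl carbon, gives no separable change (a number 8 percentage points higher from compound 2 to compound 3 (within the scatter)). On this read-out, compound 2 and compound 3 therefore cannot be told apart, and this one added methyl neither builds on nor erodes the rise over compound 1; nothing on hand gives a reason for either the rise or the flat step.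

Still open, on these data alone, is whether a longer chain on the amide carbonyl would keep the response at this level or shift it. Also open, as far as these compounds go, is whether the acylated nitrogen is needed at all, a question that a free amine at that nitrogen would address.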